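This account rests on a few compounds, and the source may have more. Where it says the series, first, only, none or still open, it means among the compounds named here.

Compound 1 `CCOC(=O)C(=O)Nc1cccc(OC)c1C#N` is the starting point of this comparison. In a functional assay on the whole organism with Rattus norvegicus as the target (on this read-out higher numbers stand for an effect only at larger amounts of compound and lower numbers for an effect already at smaller amounts), compound 1 gives 5.3 mg/kg, the highest of the three numbers measured, so it is the compound that needs the largest dose. Compound 2 `CCOC(=O)C(=O)Nc1cccc(N(C)CC)c1C#N` gives 0.3 mg/kg in this assay, and compound 3 `CCOC(=O)C(=O)Nc1cccc(N(CC)CC)c1C#N` gives 0.7 mg/kg. Both differ from compound 1 only at one aromatic carbon: an 18-fold lower number from compound 1 to compound 2 (1.25 log units; beyond the scatter), and a 7.6-fold lower number from compound 1 to compound 3 (0.88 log units; beyond the scatter). Between the two amines themselves, a 2.3-fold higher number from compound 2 to compound 3 (0.37 log units; beyond the scatter).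

Compound 4 `CCOC(=O)C(=O)Nc1cccc(N2CCCCC2)c1C#N` has not yet been measured. It differs from compound 1 in the same place as compounds 2 and 3: piperidin-1-yl in place of methoxy on an aromatic carbon. As in compounds 2 and 3, a nitrogen carrying saturated carbon now sits where the methoxy oxygen was, here closed into a six-membered ring. The two measured steps from compound 1 both lowered the number well beyond the scatter, so a drop of similar size is expected for compound 4, though the added ring carbons leave the exact amount uncertain. The estimated step is a 6.6-fold lower number from compound 1 to compound 4 (0.82 log units; beyond the scatter). For compound 4 in this assay the expected value is 0.8 mg/kg, within a range from 0.3 mg/kg to 2.5 mg/kg.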

Compound 4, dose for half-maximal effect: 2.2 mg/kg
Beside the measured number, compound 4's estimate is 2.8-fold (0.44 log units) below it, within the range that was stated.
By their numbers in this assay, from the lowest: compound 2; then compound 3; then compound 4; then compound 1.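

In this assay, piperidin-1-yl in place of methoxy still gives a 2.4-fold lower number from compound 1 to compound 4 (0.38 log units; beyond the scatter), so all three nitrogen groups shown at this aromatic carbon, ortho to a cyano group, give lower numbers than methoxy. Tying the nitrogen's substituents into a six-membered ring, however, costs much of that gain: the change to the ring gives a 3.1-fold higher number from compound 3 to compound 4 (0.50 log units; beyond the scatter), and the comparison with the smaller open-chain amine gives a 7.3-fold higher number from compound 2 to compound 4 (0.87 log units; beyond the scatter). A nitrogen at this place is therefore not enough by itself to reach the lowest numbers, since what the nitrogen carries also shifts the dose needed, and here the two open-chain amines both do better than the ring.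

The compounds shown leave open whether the ring itself or its size sets this result, which a five-membered pyrrolidin-1-yl ring, or a morpholin-4-yl ring with oxygen as a second ring atom, would help to separate. No measurement offered here explains why the ring falls behind the open-chain amines.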